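A few compounds are considered here, and "the series" means these few. Any claim that something is new, unique, unknown or untested is made for them only; others in the source may bear on it.

Values in a functional assay on HL-60 cells (Homo sapiens) for inhibition, read by MTT assay, with a stated time of 72 h; on this read-out higher numbers stand for weaker inhibition and lower numbers for stronger inhibition:
- compound 1 `O=C(c1oc(C(F)(F)F)nc1-c1ccccc1F)N1CCN(c2cccc(Cl)c2)CC1`: "not active" (no number reported)
- compound 2 `Cc1nc(-c2ccccc2)c(C(=O)N2CCN(c3cccc(C(N)=O)c3)CC2)o1`: 71 nM
- compound 3 `Cc1ccc(C)c(N2CCN(C(=O)c3oc(C)nc3-c3ccccc3F)CC2)c1`: 319 nM

Compound 2, at 71 nM, holds the lower of the two numbers. Compound 3, at 319 nM, lies higher by a gap beyond the usual scatter, and compound 1 gives no number.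

Next in the series is compound 4 `Cc1nc(-c2ccccc2)c(C(=O)N2CCN(c3ccc(C(F)(F)F)cc3)CC2)o1`, which has 4-(trifluoromethyl)phenyl in place of 3-carbamoylphenyl on an amine nitrogen in a ring. Among the measured compounds shown here, no measured pair isolates this change, so the expectation rests on indirect evidence. Neither compound 3, at 319 nM, nor compound 1, at "not active" (no number reported), carries 3-carbamoylphenyl, although both also differ from compound 2 elsewhere. The expected step is a 4.2-fold higher number from compound 2 to compound 4 (0.63 log units; beyond the scatter), towards weaker inhibition and beyond the scatter. For compound 4 the estimate is 300 nM, with an expected range of 60 nM to 1500 nM.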

Compound 4, half-maximal inhibitory concentration: > 1000 nM
Compound 4 ended at the assay's limit; the forecaster's own chance of this, stated with the estimate: 20%; middle value at least 3.3-fold (0.52 log units) from the limit.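

In this assay, 4-(trifluoromethyl)phenyl in place of 3-carbamoylphenyl on an amine nitrogen in a ring gives an at least 14-fold higher number from compound 2 to compound 4 (1.14 log units; beyond the scatter), the only one-place comparison in the compounds shown, so the group at this position clearly affects the read-out, with the change running towards weaker inhibition. Compound 4 gives > 1000 nM, which is a limit of the assay and not a number. The step therefore fixes only a minimum size, and the true gap stays unknown: the limit of > 1000 nM in this assay, at which 1 of the 4 values shown sits.

The change replaces the carbamoyl group with trifluoromethyl and also alters where the substituent sits on the phenyl ring, and these two differences cannot be separated here. A phenyl ring carrying a carboxylic acid, a nitrile or no further group on the same nitrogen would show how far inhibition depends on the carbamoyl group itself.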